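The source may report more compounds than this note shows. Statements on the series, on what has been measured and on what is new or still open speak of the compounds shown alone.

- Compound 1 `Cc1cc(=O)c(O)c(CN2CCCCC2)n1C`: 2.5
- Compound 2 `O=c1cc(CN2CCCCC2)n(CCN2CCCCC2)cc1O`: 1.16

Both values come from a physicochemical assay for acid dissociation, using potentiometric titration. Compound 2 stands lowest of the two measured compounds at 1.16, and the gap up to compound 1 lies beyond the usual scatter.

Compound 3 `Cn1cc(O)c(=O)cc1CN1CCCCC1` has not yet been measured. It differs from compound 2 in a single place, with hydrogen in place of (piperidin-1-yl)methyl on a saturated chain carbon bound to an aromatic nitrogen.

Among the measured compounds shown here, no measured pair shows this change on its own, so its size cannot be read directly from the data. The nearest guide is compound 1 at 2.5, whose structure is closer to that of compound 3 than the structure of compound 2 is. On that basis, this assay is expected to show a rise beyond the scatter, and the estimated step is a number 1.04 log units higher from compound 2 to compound 3 (beyond the scatter). The estimate for compound 3 is 2.2, with an expected range from 1.6 to 2.9.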

Compound 3, acid dissociation constant: 2.15
Compound 3: the middle estimate sits 0.05 log units above what was measured, and the stated range covers the measured number.
By their numbers in this assay, from the lowest: compound 2; then compound 3; then compound 1.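

Among the compounds shown here, putting hydrogen in place of (piperidin-1-yl)methyl on a saturated chain carbon bound to an aromatic nitrogen gives a number 0.99 log units higher from compound 2 to compound 3 (beyond the scatter) in this assay as the first direct reading of this change on its own. The earlier compounds shown here could not isolate this place, but this single pair shows that the read-out responds to what is attached there: the proton is given up less readily with hydrogen than with the group of 7 heavy atoms that includes a six-membered non-aromatic ring. No measurement at hand explains the size or direction of this step.

One pair gives one direction at one place, so it cannot separate the contribution of the piperidine ring from that of the methylene carbon linking it to the chain. As far as these compounds go, a cyclohexylmethyl group, a morpholin-4-ylmethyl group or a simple methyl group in the same place would each test a different part of the departing group, and whether the step would shrink, hold or reverse with them remains open.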